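The compounds below may be only part of what the source reports. "The series", "measured", "known", "first", "only" and "open" are said of these compounds alone.

Compound 1 `Cc1ccc(Nc2nc(C)c(C(=O)/C=C/c3ccc(Cl)cc3)s2)cc1`: in a functional assay on PC-3 cells (Homo sapiens) for cytotoxicity, read by MTT assay (on this read-out lower numbers stand for stronger inhibition and higher numbers for weaker inhibition), compound 1 gives only the limit > 25000 nM.
Compound 2 `Cc1nc(Nc2ccc(Cl)cc2)sc1C(=O)/C=C/c1ccc(Cl)cc1`: in this assay compound 2 gives only the limit > 25000 nM.
Compound 3 `Cc1ccc(Nc2nc(C)c(C(=O)/C=C/c3ccccc3)s2)cc1`: not yet measured in this assay.

From the compounds shown here alone, compound 1 stands at a limit of this assay, so its true place among the numbers is unknown. Going by the values given here, the single measured step, a step that the two limits leave unreadable from compound 1 to compound 2, cannot be read, since both of its ends sit at the same limit (the limit of > 25000 nM in this assay, at which 2 of the 2 values shown sit). The change to compound 3 is hydrogen in place of chloro on an aromatic carbon. No readable measured step bears on this change, so neither a direction nor a size beyond the scatter can be expected from the data. Compound 3 is therefore expected to give 40000 nM, with a range from 10000 nM to 150000 nM, most likely again reported only as a limit. The estimated step is a step that the limit leaves unreadable from compound 1 to compound 3.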

Compound 3, half-maximal inhibitory concentration: > 25000 nM
Compound 3 was reported as a limit; the forecaster's own chance of this, stated with the estimate: 80%; the middle value lies beyond the limit too.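

The step from compound 1 to compound 3 cannot be read, as both compounds give only a limit: the limit of > 25000 nM in this assay, at which 3 of the 3 values shown sit. The compounds shown leave open where each truly lies, and whether changing 4-chlorophenyl to phenyl alters cytotoxicity at all.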